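From Acetyl to Carboxy: Expected Cytotoxicity of Compound 4

The source may hold more compounds than are shown below. What is called first, only, known or untested is meant among the compounds shown, and "the series" means these compounds.

Measured so far:
- Compound 1 `CC(=O)c1ccc(NC(=O)Nc2cc(C)nc3ccccc23)cc1` gives 22000 nM.
- Compound 2 `COc1ccc(NC(=O)Nc2cc(C)nc3ccccc23)cc1OC` gives > 25000 nM, a limit of the assay rather than a number.
- Compound 3 `Cc1cc(NC(=O)Nc2ccccc2C(F)(F)F)c2ccccc2n1` gives > 25000 nM, again a limit and not a number.

All three were tested in an ADME assay on BJ cells (Homo sapiens) for cytotoxicity, with a stated time of 72 h; on this read-out higher numbers stand for an effect only at larger amounts of compound and lower numbers for an effect already at smaller amounts. For the measured compounds named here, compound 1 stands as the only compound with an actual number in this assay; the other two values sit at the limit of > 25000 nM in this assay, at which 2 of the 3 values shown sit, so nothing can be said about their order relative to compound 1 beyond the fact that compound 1 was the one to show an effect within the tested range.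

Compound 4 `Cc1cc(NC(=O)Nc2ccc(C(=O)O)cc2)c2ccccc2n1` has not yet been measured. It differs from compound 1 in one place: hydroxy in place of methyl on a carbonyl carbon. Seen one bond further out, the acetyl of compound 1 becomes a carboxy in compound 4.

Going by the values given here, with no measured step to lean on, the expectation rests on the three values alone. The step of a 1.4-fold higher number from compound 1 to compound 4 (0.13 log units; within the scatter) is expected to be small, if anything toward an effect only at larger amounts of compound, because two of the three measured compounds already sit at the limit of > 25000 nM in this assay, at which 2 of the 3 values shown sit. Compound 4 is therefore estimated at 30000 nM, within 15000 nM to 60000 nM, with a real chance that only a limit is reported.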

Compound 4, half-maximal effective concentration: > 25000 nM
Compound 4 was reported as a limit (the forecaster's own chance of this, stated with the estimate: 65%); the middle value lies beyond the limit too.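

For the compounds shown here, compound 1 and compound 4 are the first pair here that differ in one place, so a single change can finally be read: hydroxy in place of methyl on a carbonyl carbon, which turns the acetyl into a carboxy. In this assay, this change reads as an at least 1.1-fold higher number from compound 1 to compound 4 (0.05 log units; that floor lies within the scatter), so it shows no shift beyond the usual scatter, although the true step could be larger, as the value of compound 4 is a limit and not a number. The result does show that this position accepts a carboxy without any effect appearing in the tested range, and that a limit is now the most common result in this small set: the limit of > 25000 nM in this assay, at which 3 of the 4 values shown sit.

On these data alone, it remains open whether an amine on the same carbonyl carbon, or a longer chain such as ethyl in place of the methyl, would bring the effect to smaller or larger amounts of compound. As far as these compounds go, how far the true value of compound 4 lies from that of compound 1 also stays unknown, and a more sensitive read-out over a wider range of amounts would be needed to settle it.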